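Cyclobutyl in place of ethyl on the acyl group

A few compounds are considered here, and "the series" means these few. Any claim that something is new, unique, unknown or untested is made for them only; others in the source may bear on it.

Of the compounds shown here, three sharing one core have been measured in an assay on Sf9 cells for inhibition of mitogen-activated protein kinase kinase kinase 14 (Homo sapiens), read by ADP-Glo, with a stated time of 60 min; on this read-out lower numbers stand for stronger inhibition and higher numbers for weaker inhibition. For compound 1 `Cc1[nH]nc(N)c1-c1cccc(Br)c1` the assay reports only a limit, > 100000 nM, and not a number. Compound 2 `Cc1n[nH]c(N)c1-c1ccc(Cl)cc1` gives 61100 nM in this assay. Compound 3 `CCC(=O)n1nc(C)c(-c2ccc(Cl)c(Cl)c2)c1N` gives 27400 nM in this assay, which is the lowest of the two numbers recorded; the number for compound 2 stands higher, and that gap lies beyond the usual scatter. Among the measured compounds shown here, the two compounds with numbers differ in more than one place, so no single step between them can be read off.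

Compound 4 `Cc1nn(C(=O)C2CCC2)c(N)c1-c1ccc(Cl)c(Cl)c1` is not yet measured in this assay. It differs from compound 3 in one place: cyclobutyl in place of ethyl on a carbonyl carbon. For the measured compounds named here, no measured pair among the three compounds changes this position, so there is nothing to set the size of the step against. Since the two groups are both saturated carbon chains of similar extent, a step from compound 3 to compound 4 of a 1.2-fold lower number from compound 3 to compound 4 (0.10 log units; within the scatter) is expected, small and most likely within the scatter. Compound 4 is therefore estimated at 22000 nM in this assay, with a range from 8000 nM to 60000 nM.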

Compound 4, half-maximal inhibitory concentration: 2900 nM
Compound 4: the middle estimate sits 7.6-fold (0.88 log units) above what was measured; measured number below the stated range.
By their numbers in this assay, from the lowest: compound 4; then compound 3; then compound 2. At a limit, above all of these: compound 1.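

In this assay, the group on the carbonyl carbon turns out to matter: cyclobutyl in place of ethyl gives a 9.4-fold lower number from compound 3 to compound 4 (0.98 log units; beyond the scatter). Among the compounds shown here, this is the first readable step at this position, and it shows that the read-out responds to a change that brings in no hydrogen-bond donor, hydrogen-bond acceptor or net charge on either side, only a move from 2 to 4 heavy atoms, all carbon, and a four-membered non-aromatic ring. Nothing measured among these compounds gives a cause for the step.

Going by these compounds, what remains open is whether the ring itself or the added carbon accounts for the step, since a single pair cannot separate the two, and an open butanoyl chain, a cyclopropyl ring or a cyclohexyl ring would each bear on that question. On these data alone, it is also open how far this position tolerates other groups, such as an amine or a carboxylic acid on the acyl group, and whether the same step would appear with a different substitution on the aromatic ring of compound 3.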